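This account rests on a few compounds, and the source may have more. Where it says the series, first, only, none or still open, it means among the compounds named here.

In a functional assay on MT4 cells (Homo sapiens) for cytotoxicity (a lower number here means that less compound is tolerated, a higher number that more compound is tolerated), the two measured compounds gave these values:

compound 1 `CC(C)(C)[Si](C)(C)OC[C@H]1O[C@@H](n2cnc3c(N)ncnc32)[C@H](O[Si](C)(C)C(C)(C)C)[C@]12OS(=O)(=O)C=C2N`: 13000 nM
compound 2 `COc1ncnc2c1ncn2[C@@H]1O[C@H](CO[Si](C)(C)C(C)(C)C)[C@@]2(OS(=O)(=O)C=C2N)[C@H]1O[Si](C)(C)C(C)(C)C`: 21000 nM

Going by the values given here, compound 2 gives the highest of the two numbers in this assay, but its only neighbour is compound 1, and the step of a 1.6-fold higher number from compound 1 to compound 2 (0.21 log units; within the scatter) is within the scatter, so the two compounds cannot be told apart on this evidence.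

Compound 3 `CC(C)(C)[Si](C)(C)OC[C@H]1O[C@@H](n2c(=O)[nH]c(=O)c3[nH]cnc32)[C@H](O[Si](C)(C)C(C)(C)C)[C@]12OS(=O)(=O)C=C2N` has not yet been measured. It differs from compound 2 in the group attached to the saturated ring carbon of the shared core: a group of 11 heavy atoms (5 carbon, 4 nitrogen, 2 oxygen; one five-membered aromatic ring with 2 hetero atoms, one six-membered aromatic ring with 2 hetero atoms) in place of a group of 11 heavy atoms (6 carbon, 4 nitrogen, 1 oxygen; one five-membered aromatic ring with 2 hetero atoms, one six-membered aromatic ring with 2 hetero atoms), on a saturated ring carbon

Among the compounds with values here, only one measured step exists, a 1.6-fold higher number from compound 1 to compound 2 (0.21 log units; within the scatter), and it swapped a small group on the same aromatic system rather than replacing the whole bicyclic group, so it bears on the new change only loosely. That step stayed within the scatter, and nothing here suggests the larger replacement will move tolerability far either way. The expected step is therefore small, a 1.2-fold higher number from compound 2 to compound 3 (0.08 log units; within the scatter), with a wide band of uncertainty. Compound 3 is estimated at 25000 nM in this assay, with a likely range from 10000 nM to 70000 nM.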

Compound 3, half-maximal cytotoxic concentration: 14000 nM
Compound 3: middle estimate off by 1.8-fold (0.25 log units), on the high side; the range from low to high includes it.
By their numbers in this assay, from the lowest: compounds 1, 3 and 2 (each within the scatter of the next).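

The earlier pair changed only a small group on one aromatic system, whereas this result concerns the whole group on the saturated ring carbon next to the ring oxygen. Even so, this assay shows a 1.5-fold lower number from compound 2 to compound 3 (0.18 log units; within the scatter) for a group with 2 hydrogen-bond donors and 2 double bonds outside aromatic rings in place of one with 0 hydrogen-bond donors, and a 1.1-fold higher number from compound 1 to compound 3 (0.03 log units; within the scatter) for the exchange of the 10-heavy-atom group, so on these three compounds neither replacement of the whole group can be told from repeat-measurement noise. Nothing shown here offers an explanation for how closely these values sit together.

On these data alone, whether a group with no aromatic ring at all, such as a plain amine or a longer carbon chain, on that saturated ring carbon would give a value clearly apart from these remains open. Also open is what the shared core contributes to tolerability, including its silyl ethers, as every compound shown carries it unchanged.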